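The source may report more compounds than this note shows. Statements on the series, on what has been measured and on what is new or still open speak of the compounds shown alone.

Measured compounds:
Compound 1 `COCCN(C)S(=O)(=O)c1ccc(C)c(C#Cc2cc(Cl)ccc2OCC(=O)O)c1`: in an ADME assay on a cell-free system (plasma, Mus musculus) (on this read-out lower numbers stand for a smaller free fraction and higher numbers for a larger free fraction), compound 1 gives 0.007.
Compound 2 `Cc1ccc(S(=O)(=O)CC(C)C)cc1C#Cc1cc(Cl)ccc1OCC(=O)O`: in this assay compound 2 gives "not determined" (no result reported).

Compound 2 stands without a number in this assay; the only read-out in the series is that of compound 1, so nothing shows where compound 2 sits relative to it. Compound 3 `Cc1ccc(S(C)(=O)=O)cc1C#Cc1cc(Cl)ccc1OCC(=O)O` differs from compound 2 by hydrogen in place of isopropyl on a saturated chain carbon bound to a sulfonyl sulfur. Within the data shown here, with no measured pair to lean on, the step from compound 2 to compound 3 in this assay is expected to be modest, a rise near the edge of the scatter being more likely than a fall. The unbound fraction of compound 3 is estimated at 0.02, between 0.007 and 0.06.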

Compound 3, unbound fraction: 0.027
Beside the measured number, compound 3's estimate is 1.4-fold (0.13 log units) below it; the measured number falls inside the stated range.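

Among these compounds, the first readable step on a sulfonyl sulfur comes from methyl in place of (2-methoxyethyl)(methyl)amino, which gives a 3.9-fold higher number from compound 1 to compound 3 (0.59 log units; beyond the scatter) in this assay on this one pair. The group on that sulfur can therefore shift the unbound fraction beyond the scatter. Nothing available explains the step.

The step between compound 2 and compound 3 cannot be read, so isobutyl remains unplaced against methyl. On these data alone, how a cyclopropyl group, an amine or a longer chain on the sulfonyl sulfur would read in this assay also stays open.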